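From Butyl to Cyclopentyl on the Ring Nitrogen

The source may hold more compounds than are shown below. What is called first, only, known or untested is meant among the compounds shown, and "the series" means these compounds.

Measured so far:
compound 1, `CC(C)n1cnc2c(Nc3ccccc3)nc(NCOCc3ccc(/C=C/C(=O)Nc4ccccc4N)cc3)nc21`: 41%
compound 2, `Nc1ccccc1NC(=O)c1ccc(COCNc2nc(Nc3ccccc3)c3ncn(C4CCCC4)c3n2)cc1`: 41.2%
compound 3, `CCCCn1cnc2c(Nc3ccccc3)nc(NCOCc3ccc(/C=C/C(=O)Nc4ccccc4N)cc3)nc21`: 23.1%

In a functional assay on NCI-H460 cells (Homo sapiens) for antiproliferative activity, read by CCK-8 assay, with a stated time of 72 h, tested at 2 uM (a higher number here means a stronger effect of the compound at the concentration tested, a lower number a weaker effect), compound 3 gives the lowest of the three numbers. Among the measured compounds shown here, its nearest neighbour is compound 1, and the only measured step that differs in a single place, a number 17.9 percentage points lower from compound 1 to compound 3 (beyond the scatter), lies beyond the scatter; compound 2 stands a similar distance above compound 3.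

Compound 4, `Nc1ccccc1NC(=O)/C=C/c1ccc(COCNc2nc(Nc3ccccc3)c3ncn(C4CCCC4)c3n2)cc1`, has not yet been measured in this assay. It differs from compound 3 as follows: cyclopentyl in place of butyl on an aromatic nitrogen. The step that bears on this change is a number 17.9 percentage points lower from compound 1 to compound 3 (beyond the scatter), which shows that a butyl group at this nitrogen, in place of isopropyl, lowered the read-out by a modest amount. Compound 2, which carries the cyclopentyl group that enters here but a different linker to the aminophenyl amide, gives 41.2%, close to compound 1. For the measured compounds named here, no step between compound 2 and compound 4 is available, so that likeness is only suggestive.

On this basis the cyclopentyl group is expected to recover much of the loss seen with butyl, so a step upward of about a number 14.9 percentage points higher from compound 3 to compound 4 (beyond the scatter) is estimated, with wide uncertainty. Compound 4 is therefore expected to give 38%, within a range from 22% to 52%.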

Compound 4, a percentage reported as inhibition, at one concentration (the size of the read-out at that concentration, not a potency): 52%
Estimate against measurement, compound 4: 14 percentage points below; measured number inside the range.
By their numbers in this assay, from the lowest: compound 3; then compounds 1 and 2 (each within the scatter of the next); then compound 4.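

In this assay, cyclopentyl in place of butyl on an aromatic nitrogen brings a number 28.9 percentage points higher from compound 3 to compound 4 (beyond the scatter), so the butyl loss seen earlier is not a general penalty for a larger carbon group at this position. Cyclopentyl in place of isopropyl also gives a number 11 percentage points higher from compound 1 to compound 4 (beyond the scatter), which places the three groups on this nitrogen, with the rest of the molecule unchanged, in the order butyl, isopropyl, cyclopentyl, each step beyond the scatter. Among the compounds shown here, with cyclopentyl held fixed, 2-((2-aminophenyl)carbamoyl)ethenyl in place of (2-aminophenyl)carbamoyl on an aromatic carbon gives a number 10.8 percentage points higher from compound 2 to compound 4 (beyond the scatter), the first reading of that change on its own. Nothing shown here measures why these groups differ in this way.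

The compounds shown leave open whether a cyclopropyl or cyclohexyl ring, or a chain ending in a hydroxyl or an amine, on this nitrogen would continue the same order. They also leave open whether the order holds at other concentrations, since each number is a single read-out at one concentration and not a potency.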